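The source may hold more compounds than are shown below. What is called first, only, known or untested is meant among the compounds shown, and "the series" means these compounds.

Three compounds of this series have been examined in an ADME assay on HOS cells (Homo sapiens) for cytotoxicity; on this read-out higher numbers stand for weaker inhibition and lower numbers for stronger inhibition. Compound 1, `O=C1c2c(ccc(O)c2O)CN1Cc1cccc(F)c1`, gives 8600 nM in this assay. Compound 3, `O=C1c2c(ccc(O)c2O)CN1Cc1cc(F)ccc1F`, differs from compound 1 in one place, (fluoro in place of hydrogen on an aromatic carbon), and in this assay compound 3 gives 13400 nM; the step is a 1.6-fold higher number from compound 1 to compound 3 (0.19 log units; within the scatter). Compound 2, `O=C1c2ccc(O)c(O)c2C(=O)N1Cc1cccc(Cl)c1`, is built on a different core, and the difference between the two cores is not broken down here. In this assay compound 2 gives 13300 nM, a value that is within the scatter of the values of compound 1 and compound 3, so no order among the three can be read from these numbers.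

Compound 4, `O=C1c2ccc(O)c(O)c2C(=O)N1Cc1cccc(Cl)c1F`, has not yet been measured. It differs from compound 2 in one place, (fluoro in place of hydrogen on an aromatic carbon). Going by the values given here, this is the same kind of change as the one from compound 1 to compound 3, though the surroundings differ: in compound 3 the entering fluoro is para to a fluoro group, whereas in compound 4 it is ortho to a chloro group. Because the step from compound 1 to compound 3 was a 1.6-fold higher number from compound 1 to compound 3 (0.19 log units; within the scatter), a step of similar size, a 1.3-fold higher number from compound 2 to compound 4 (0.11 log units; within the scatter), is expected from compound 2 to compound 4 in this assay. On that basis compound 4 is estimated to give 17000 nM in this assay, with a range from 8000 nM to 36000 nM expected to hold most repeat measurements.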

Compound 4, half-maximal inhibitory concentration: 11500 nM
Estimate against measurement, compound 4: 1.5-fold (0.17 log units) above, within the range that was stated.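

In this assay, placing fluoro on an aromatic carbon of compound 2 gives a 1.2-fold lower number from compound 2 to compound 4 (0.06 log units; within the scatter). Set beside the earlier case, the two steps do not differ by more than the scatter allows: the same change on two cores in this assay, a 1.6-fold higher number (0.19 log units; within the scatter) from compound 1 to compound 3 and a 1.2-fold lower number (0.06 log units; within the scatter) from compound 2 to compound 4, 1.8-fold (0.26 log units) apart, within the scatter of two such steps. This shows that, in these two pairs, the change stays within the scatter on either core and that the numbers do not separate its outcome on one core from that on the other, but it does not show that the change is without effect in general or that it would carry over in the same way to further cores, as each core offers a single pair and the surroundings of the entering fluoro differ between the two.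

The compounds shown carry only fluoro and chloro groups on the six-membered aromatic ring of carbon only, which leaves open how the read-out would respond to a methoxy group, a nitrile or a carboxylic acid in that ring. They also leave open how the same fluoro change would read on the core of compound 2 without the chloro group, and whether any single change in this series gives a step in this assay that lies beyond the scatter.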